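A few compounds are considered here, and "the series" means these few. Any claim that something is new, unique, unknown or untested is made for them only; others in the source may bear on it.

Compound 1 `CCOC(=O)C(C)Oc1ccc(NC(=O)COc2ccccc2C(C)CC)cc1` was run in a functional assay for inhibition, read by spectrophotometry, tested at 200 ug/mL (a lower number here means less inhibition, a higher number more inhibition at the concentration tested (going by the name of the read-out)), where compound 1 gives 25%. The second measured compound, compound 2 `CCOC(=O)C(C)Oc1ccc(NC(=O)COc2ccc3ccccc3c2)cc1`, gives 25% in this assay. The two results are level at the digits shown and fall within the usual scatter of each other, so nothing separates compound 1 from compound 2 here; compound 1 simply stands where compound 2 stands.

Compound 3 `CCOC(=O)C(C)Oc1ccc(NC(=O)COc2ccccc2Cl)cc1` has not yet been measured. It differs from compound 1 in one place: chloro in place of sec-butyl on an aromatic carbon. Going by the values given here, no measured pair shows a change of this kind, so there is no step of known size to lean on, and the only anchor is the value of compound 1. The step that is expected is no change at the digits printed from compound 1 to compound 3 (within the scatter), a change no larger than the scatter in either direction. Compound 3 is therefore estimated at 25%, with a likely range from 10% to 45%.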

Compound 3, a percentage reported as inhibition, at one concentration (the size of the read-out at that concentration, not a potency): 33%
For compound 3 the middle estimate is 8 percentage points below the measured one; low and high end bracket the measured number.
By their numbers in this assay, from the lowest: compounds 1, 2 and 3 (each within the scatter of the next).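

In this assay, putting chloro in place of sec-butyl on an aromatic carbon, ortho to a large group, gives a number 8 percentage points higher from compound 1 to compound 3 (within the scatter) and so leaves the two compounds indistinguishable. Going by these compounds alone, this is the first one-place change seen at this position, and it shows that a group of 4 heavy atoms, all carbon, can give way to a single chlorine atom without a change that stands clear of the scatter in this read-out. Nothing available explains this result or says what either group contributes. Still open, going by these compounds, is whether a quite different group at this position, such as an amine or a methoxy group, would move the read-out beyond the scatter. Also open, on these data alone, is how these compounds would compare across a range of concentrations, since a single tested concentration gives no potency.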